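The source may report more compounds than this note shows. Statements on the series, on what has been measured and on what is new or still open speak of the compounds shown alone.

Measured so far:
compound 1, `Cc1ccnc2nc(-c3cccc4ccccc34)cc(O)c12`, < 10 nM in a functional assay on NCI-H460 cells (Homo sapiens) for antiproliferative activity; on this read-out higher numbers stand for weaker inhibition of growth and lower numbers for stronger inhibition of growth (a limit of the assay, not a number);
compound 2, `Cc1cc(C)c2c(O)cc(-c3cccc4ccccc34)nc2n1`, 631 nM;
compound 3, `Cc1ccc2c(O)cc(-c3ccc4ccccc4c3)nc2n1`, 3800 nM.

The value of compound 1 sits at a limit of this assay, (the limit of < 10 nM in this assay, at which 1 of the 3 values shown sits). Compound 2 carries the change (methyl in place of hydrogen on an aromatic carbon), and the step is an at least 63-fold higher number from compound 1 to compound 2 (1.80 log units; beyond the scatter). Compound 3 differs from compound 1 in its core; that difference between the two cores is not broken down here. Compound 3 gives the highest number of the two counted values, and compound 2 stands a good deal lower.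

Compound 4, `Cc1cc(C)c2c(O)cc(-c3ccc4ccccc4c3)nc2n1`, is not yet measured. It differs from compound 3 by methyl in place of hydrogen on an aromatic carbon, the same kind of change as that from compound 1 to compound 2, though the methyl enters at a different place: ortho to a fused ring and opposite the ring nitrogen, rather than next to the ring nitrogen and para to a fused ring. Since compound 3 already gives 3800 nM, a step of the size a 3.9-fold higher number from compound 3 to compound 4 (0.60 log units; beyond the scatter) is expected in this assay, smaller than the measured one, because that step an at least 63-fold higher number from compound 1 to compound 2 (1.80 log units; beyond the scatter) started from a limit. Compound 4 is therefore estimated at 15000 nM, roughly within 3000 nM to 60000 nM.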

Compound 4, concentration for 50% growth inhibition: 13200 nM
Estimate against measurement, compound 4: 1.1-fold (0.06 log units) above, and the stated range covers the measured number.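

On both cores in this assay, methyl in place of hydrogen on an aromatic carbon goes with weaker inhibition of growth, and the new step is a 3.5-fold higher number from compound 3 to compound 4 (0.54 log units; beyond the scatter). The direction of the change therefore carries from one core to the other in these two pairs, but its size does not: the same change on two cores in this assay, an at least 63-fold higher number (1.80 log units; beyond the scatter) from compound 1 to compound 2 and a 3.5-fold higher number (0.54 log units; beyond the scatter) from compound 3 to compound 4, at least 18-fold (1.25 log units) apart, beyond the scatter of two such steps Compound 1 sits at a limit of the assay and has no exact number, so the full size of the earlier step stays unknown, and these pairs cannot show whether the gap between the steps follows from the core or from the different place where the methyl enters: the limit of < 10 nM in this assay, at which 1 of the 4 values shown sits.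

From the compounds shown here alone, what an ethyl group, a longer chain, a methoxy group or an amine would do in place of this methyl remains open. So does the size of the methyl step on any core beyond these two.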